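Trimming an Ethyl Branch from the Amide Side Chain

A few compounds are considered here, and "the series" means these few. Any claim that something is new, unique, unknown or untested is made for them only; others in the source may bear on it.

Among the compounds with values here, compound 3 `CCC(CO)NC(=O)c1cc2cccc(OC)c2oc1=N` is the only member of this set with a plain number in an assay on HEK293 cells for displacement of a labelled ligand from adenosine receptor A2b (Homo sapiens), read by scintillation counting, with a stated time of 30 min, tested at 10 uM (on this read-out lower numbers stand for less inhibition and higher numbers for more inhibition at the one concentration tested (going by the name of the read-out)), where compound 3 gives 39%. Compound 1 `COc1cccc2cc(C(=O)NC3CCCCC3)c(=N)oc12` reaches only a limit, > 70%. Compound 2 `COc1cccc2cc(C(=O)NCCCCCO)c(=N)oc12` likewise reaches only a limit, > 70%. Both rest at the limit of > 70% in this assay, at which 2 of the 3 values shown sit. The steps of a number at least 31 percentage points lower from compound 1 to compound 3 (beyond the scatter) and a number at least 31 percentage points lower from compound 2 to compound 3 (beyond the scatter) are large, while a step that the two limits leave unreadable from compound 1 to compound 2 cannot be sized. Compound 4 `COc1cccc2cc(C(=O)NCCO)c(=N)oc12` differs from compound 3 by hydrogen in place of ethyl on a saturated chain carbon bound to an amide-type nitrogen and a saturated chain carbon. Within the data shown here, no measured step removes exactly this branch; yet since a number at least 31 percentage points lower from compound 2 to compound 3 (beyond the scatter) exchanged an unbranched hydroxyl chain for the branched one and was large, taking the branch away is expected to recover part of that loss. An upward step of a number 16 percentage points higher from compound 3 to compound 4 (beyond the scatter) is expected. Compound 4 is therefore estimated at 55%, from 30% to 80%.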

Compound 4, a percentage reported as inhibition, at one concentration (the size of the read-out at that concentration, not a potency): 65%
The estimate for compound 4 lay 10 percentage points below the measured number; low and high end bracket the measured number.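

In this assay, within the data shown here, taking away the ethyl branch alone gives a number 26 percentage points higher from compound 3 to compound 4 (beyond the scatter), so this chain carbon matters by itself, something no earlier step isolated. The unbranched 2-hydroxyethyl chain shows no clear loss against the other two side chains, with a number at least 5 percentage points lower from compound 2 to compound 4 (that floor lies within the scatter) and a number at least 5 percentage points lower from compound 1 to compound 4 (that floor lies within the scatter). Both of these steps stay open-ended, since compounds 1 and 2 give only a limit: the limit of > 70% in this assay, at which 2 of the 4 values shown sit.

As far as these compounds go, whether a smaller methyl branch on that carbon would keep the inhibition remains open. So does the effect of an amine or a carboxylic acid in place of the hydroxy group.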